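The source may report more compounds than this note shows. Statements on the series, on what has been measured and on what is new or still open speak of the compounds shown alone.

Compounds measured in a functional assay on CHP-134 cells (Homo sapiens) for antiproliferative activity, with a stated time of 72 h (on this read-out higher numbers stand for weaker inhibition and lower numbers for stronger inhibition), are these:

Compound 1 `Cc1ccc(NC(=O)CCN(Cc2ccc(C(=O)NO)cc2)C(=O)c2cc(C)cc(C)c2)cc1` gives 380 nM
Compound 2 `Cc1cc(C)cc(C(=O)N(CCC(=O)NCc2ccccc2)Cc2ccc(C(=O)NO)cc2)c1` gives 2030 nM
Compound 3 `CN(C)c1ccc(C(=O)N(CCC(=O)NCc2ccc(Cl)cc2)Cc2ccc(C(=O)NO)cc2)cc1` gives 610 nM

Compound 2 holds the highest number of the three. Compound 4 `COc1ccc(C(=O)N(CCC(=O)NCc2ccccc2)Cc2ccc(C(=O)NO)cc2)cc1` is still unmeasured and differs from compound 2 by 4-methoxyphenyl in place of 3,5-dimethylphenyl on a carbonyl carbon. Within the data shown here, the only measured single-place step, a 5.3-fold higher number from compound 1 to compound 2 (0.73 log units; beyond the scatter), lies on an amide-type nitrogen, not at this carbonyl, so it gives no direct guide. Compound 3, at 610 nM, has a lower number than compound 2 but differs in more than one place. Only a small downward move is therefore expected, a 1.7-fold lower number from compound 2 to compound 4 (0.23 log units; within the scatter), not beyond the scatter. For compound 4 the estimated value in this assay is 1200 nM, with an expected range from 500 nM to 2800 nM.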

Compound 4, half-maximal inhibitory concentration: 1900 nM
Compound 4: the middle estimate sits 1.6-fold (0.20 log units) below what was measured, and the stated range covers the measured number.
By their numbers in this assay, from the lowest: compounds 1 and 3 (each within the scatter of the next); then compounds 4 and 2 (each within the scatter of the next).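

In this assay, 4-methoxyphenyl in place of 3,5-dimethylphenyl on a carbonyl carbon gives a 1.1-fold lower number from compound 2 to compound 4 (0.03 log units; within the scatter), which is within the scatter. Among these compounds, this is the first single-place reading at this carbonyl, and it shows that this exchange, which brings in one hydrogen-bond acceptor, leaves the number unresolved from that of compound 2. No measurement shown bears on why these two groups read alike.

Going by these compounds, whether a carboxylic acid on this aromatic ring would move the number remains open. Also open, on these data alone, is whether the step of a 5.3-fold higher number from compound 1 to compound 2 (0.73 log units; beyond the scatter) would recur with 4-methoxyphenyl on the carbonyl.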